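The source may report more compounds than this note shows. Statements on the series, on what has been measured and on what is new or still open speak of the compounds shown alone.

Values in a functional assay on MDA-MB-435S cells (Homo sapiens) for cytotoxicity, read by MTT assay; a higher number here means a weaker inhibitor, a lower number a stronger inhibitor:
- compound 1 `CCOC(=O)C(C)Oc1cc(O)c2c(=O)c(O)c(-c3ccc(OC)cc3)oc2c1CC=C(C)C`: 2500 nM
- compound 2 `COc1ccc(-c2oc3c(CC=C(C)C)c(OC(C)C(=O)O)cc(O)c3c(=O)c2O)cc1`: 5700 nM
- compound 3 `COc1ccc(-c2oc3c(CC=C(C)C)c(OCC(=O)O)cc(O)c3c(=O)c2O)cc1`: 13500 nM

Compound 3, at 13500 nM, has the highest number of the three and is the weakest inhibitor in this small set. The step to compound 4 `CCOC(=O)COc1cc(O)c2c(=O)c(O)c(-c3ccc(OC)cc3)oc2c1CC=C(C)C` is ethyl in place of hydrogen on an oxygen next to a carbonyl group, which turns carboxymethyl into (ethoxycarbonyl)methyl.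

Among the measured compounds shown here, the closest precedent is the same exchange in the opposite direction, where hydrogen in place of ethyl gave a 2.3-fold higher number from compound 1 to compound 2 (0.36 log units; beyond the scatter). That pair carries an added methyl on the chain, which compound 3 and compound 4 both lack. Losing that methyl gave a 2.4-fold higher number from compound 2 to compound 3 (0.37 log units; beyond the scatter), and the two changes together gave a 5.4-fold higher number from compound 1 to compound 3 (0.73 log units; beyond the scatter). For the measured compounds named here, only this one pair shows the exchange, so its transfer to the chain without the methyl remains untested.

If it does transfer, a modest shift toward stronger inhibition is expected in this assay, and the expected change is a 2.3-fold lower number from compound 3 to compound 4 (0.37 log units; beyond the scatter). The estimate for compound 4 is 5800 nM, with an expected range of 2500 nM to 13000 nM.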

Compound 4, half-maximal inhibitory concentration: 5300 nM
The estimate for compound 4 lay 1.1-fold (0.04 log units) above the measured number; measured number inside the range.
By their numbers in this assay, from the lowest: compound 1; then compounds 4 and 2 (each within the scatter of the next); then compound 3.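

In this assay, ethyl in place of hydrogen gives a 2.5-fold lower number from compound 3 to compound 4 (0.41 log units; beyond the scatter), so the exchange seen on the chain carrying the methyl also holds on the chain without it: the same change on two cores in this assay, a 2.3-fold higher number (0.36 log units; beyond the scatter) from compound 1 to compound 2 and a 2.5-fold higher number (0.41 log units; beyond the scatter) from compound 4 to compound 3, 1.1-fold (0.05 log units) apart, within the scatter of two such steps

Loss of the methyl likewise repeats with the ethyl in place, giving a 2.1-fold higher number from compound 1 to compound 4 (0.33 log units; beyond the scatter), and so this change too is seen on two cores: the same change on two cores in this assay, a 2.4-fold higher number (0.37 log units; beyond the scatter) from compound 2 to compound 3 and a 2.1-fold higher number (0.33 log units; beyond the scatter) from compound 1 to compound 4, 1.1-fold (0.05 log units) apart, within the scatter of two such steps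

The two changes thus offset each other in a 1.1-fold lower number from compound 2 to compound 4 (0.03 log units; within the scatter), which leaves (ethoxycarbonyl)methyl and 1-carboxyethyl indistinguishable on this oxygen in this assay.

The compounds shown leave open whether a longer chain such as butyl in place of ethyl on this oxygen would move the number further. They also leave open what an amide in place of the ester would do at this position.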